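A few compounds are considered here, and "the series" means these few. Any claim that something is new, unique, unknown or untested is made for them only; others in the source may bear on it.

In a functional assay on HepG2 cells (Homo sapiens) for antiproliferative activity, read by MTT assay, with a stated time of 48 h (on this read-out higher numbers stand for weaker inhibition and lower numbers for stronger inhibition), compound 1 `COc1ccc(N(C)c2ccnc(Cl)n2)cc1` gives 2120 nM and compound 2 `COc1ccc(N(C)c2ccnc(Cl)n2)cc1Cl` gives 2630 nM. These two are separated by only a 1.2-fold higher number from compound 1 to compound 2 (0.09 log units; within the scatter). Compound 3 `COc1ccc(N(C)c2ccnc(Cl)n2)cc1OCCBr` gives 7720 nM, the highest number of the three. Compound 4 `COc1ccc(N(C)c2ccnc(Cl)n2)cc1OCCCBr` is still unmeasured and differs from compound 2 by 3-bromopropoxy in place of chloro on an aromatic carbon, which is 3-bromopropoxy in place of chloro on an aromatic carbon. The closest measured change, 2-bromoethoxy in place of chloro, gave a 2.9-fold higher number from compound 2 to compound 3 (0.47 log units; beyond the scatter). The same group in place of hydrogen gave a 3.6-fold higher number from compound 1 to compound 3 (0.56 log units; beyond the scatter). Among the compounds with values here, no measured compound carries 3-bromopropoxy, but a similar modest rise in this assay is expected. The expected change is a 2.3-fold higher number from compound 2 to compound 4 (0.36 log units; beyond the scatter). Compound 4 is estimated at 6000 nM, within an expected range of 2500 nM to 14000 nM.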

Compound 4, half-maximal inhibitory concentration: 1240 nM
For compound 4 the middle estimate is 4.8-fold (0.68 log units) above the measured one; measured number below the stated range.
By their numbers in this assay, from the lowest: compounds 4, 1 and 2 (each within the scatter of the next, the first and the last beyond it); then compound 3.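

In this assay the length of the chain at this position matters: going from 2-bromoethoxy to 3-bromopropoxy gives a 6.2-fold lower number from compound 3 to compound 4 (0.79 log units; beyond the scatter) and reverses the rise seen with the shorter chain. Replacing chloro gives a 2.1-fold lower number from compound 2 to compound 4 (0.33 log units; beyond the scatter) and so the longer chain is a modest gain over chloro, while a 1.7-fold lower number from compound 1 to compound 4 (0.23 log units; within the scatter) stays within the scatter, so 3-bromopropoxy cannot be told apart from hydrogen here. Nothing available explains the gap between the two chains. Still open, from the compounds shown here alone, is whether a longer chain such as 4-bromobutoxy would continue this trend, and whether the bromine matters, which a 3-aminopropoxy group could test.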